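The compounds below may be only part of what the source reports. "The series", "measured", "known", "first", "only" and "open" are said of these compounds alone.

Series notes. In an ADME assay on HeLa cells (Homo sapiens) for cytotoxicity, read by sulforhodamine B assay, with a stated time of 48 h, tested at 10 uM (on this read-out lower numbers stand for less inhibition and higher numbers for more inhibition at the one concentration tested (going by the name of the read-out)), compound 1 `CCCCc1cn(C(c2ccccc2)c2cc3cc(Br)ccc3nc2OC)nn1` gives -2.87%, compound 2 `CCCCCc1cn(C(c2ccccc2)c2cc3cc(Br)ccc3nc2OC)nn1` gives -9.81%, and compound 3 `COc1nc2ccc(Br)cc2cc1C(c1ccccc1)n1cc(-c2cccc(F)c2)nn1` gives 9.04%, the highest of the three numbers; the steps up to it are a number 11.9 percentage points higher from compound 1 to compound 3 (beyond the scatter) and a number 18.9 percentage points higher from compound 2 to compound 3 (beyond the scatter), both beyond the scatter. Compound 4 `COc1nc2ccc(Br)cc2cc1C(c1ccccc1)n1cc(-c2ccc(F)cc2)nn1` differs from compound 3 by 4-fluorophenyl in place of 3-fluorophenyl on an aromatic carbon. Going by the values given here, the two measured steps concern the same attachment point, but each exchanges a chain for a fluorophenyl, whereas here one fluorophenyl replaces another; no measured pair shows such an exchange. Compound 4 is therefore expected to stay close to compound 3, with an estimated step of a number 1 percentage points lower from compound 3 to compound 4 (within the scatter), not beyond the scatter. The estimate for compound 4 in this assay is 8%, expected between -6% and 22%.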

Compound 4, a percentage reported as inhibition, at one concentration (the size of the read-out at that concentration, not a potency): 4.27%
Compound 4: middle estimate off by 3.7 percentage points, on the high side; measured number inside the range.
By their numbers in this assay, from the lowest: compounds 2, 1, 4 and 3 (each within the scatter of the next, the first and the last beyond it).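

In this assay, going by these compounds alone, the first exchange of one fluorophenyl for another at this aromatic carbon, 4-fluorophenyl in place of 3-fluorophenyl, gives a number 4.8 percentage points lower from compound 3 to compound 4 (within the scatter) and so separates neither isomer from the other. Against the chains, 4-fluorophenyl gives a number 14.1 percentage points higher from compound 2 to compound 4 (beyond the scatter) but only a number 7.1 percentage points higher from compound 1 to compound 4 (within the scatter) and so, unlike 3-fluorophenyl, clears the scatter against pentyl alone. No supporting data explain these numbers. As far as these compounds go, whether an unsubstituted phenyl, an amine or a carboxylic acid at this carbon would shift the number stays open. So does the effect of changing the bromine or methoxy group on the shared core.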